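Cytotoxicity notes on a fused-core series, toward compound 4

A few compounds are considered here, and "the series" means these few. Any claim that something is new, unique, unknown or untested is made for them only; others in the source may bear on it.

Measured so far in an ADME assay on MT4 cells (Homo sapiens) for cytotoxicity, read by MTT assay, with a stated time of 5 days; a higher number here means that more compound is tolerated, a lower number that less compound is tolerated:
compound 1, `NNc1nc2cc(Cl)c(Cl)cc2s1`: 80.1 ug/mL
compound 2, `O=[N+]([O-])c1ccc(-c2nnc(-c3cccnc3)n2Nc2nc3ccc(F)cc3s2)cc1`: >= 108 ug/mL, a limit of the assay
compound 3, `Fc1ccc2nc(Nn3c(-c4ccc(Cl)cc4)nnc3-c3cccnc3)sc2c1`: 92.9 ug/mL

Compound 2 gives only a limit in this assay, and that limit is the limit of >= 108 ug/mL in this assay, at which 1 of the 3 values shown sits. Compound 3 and compound 1 give numbers that lie within the scatter of each other, so the two are not separated. Among the measured compounds shown here, the one measured step, an at least 1.1-fold lower number from compound 2 to compound 3 (0.06 log units; that floor lies within the scatter), starts from a limit and therefore sets only a floor, and that floor lies within the scatter.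

Compound 4, `Clc1ccc(-c2nnc(-c3cccnc3)n2Nc2nc3ccc(Cl)cc3s2)cc1`, is to be measured in this assay. It differs from compound 3 by chloro in place of fluoro on an aromatic carbon. For the measured compounds named here, no measured step exchanges one halogen for another at this place; the single measured step, an at least 1.1-fold lower number from compound 2 to compound 3 (0.06 log units; that floor lies within the scatter), concerns a different exchange on another ring and is small. Compound 1, which itself bears chloro groups, lies within the scatter of compound 3. The expectation is therefore no step beyond the scatter, a 1.1-fold lower number from compound 3 to compound 4 (0.04 log units; within the scatter). For compound 4 the estimate in this assay is 85 ug/mL, with a range from 45 ug/mL to 140 ug/mL.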

Compound 4, half-maximal cytotoxic concentration: 54.3 ug/mL
Estimate against measurement, compound 4: 1.6-fold (0.19 log units) above, within the range that was stated.
By their numbers in this assay, from the lowest: compounds 4, 1 and 3 (each within the scatter of the next). At a limit, above all of these: compound 2.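

Among the compounds shown here, compound 4 gives the first measured exchange of one halogen for another at this place, an aromatic carbon of the six-membered aromatic ring of carbon only, and in this assay the exchange reads as a 1.7-fold lower number from compound 3 to compound 4 (0.23 log units; within the scatter). The step stays within the scatter, so chloro in place of fluoro at this position does not separate the two compounds in this assay, and the position has so far taken both halogens without a step beyond the scatter. The data shown offer no measured property that bears on a cause for this step.

Going by these compounds, whether an amine, a carboxylic acid or a methoxy group at this place would give a step beyond the scatter stays open, as does whether the same halogen exchange reads alike with nitro in place of chloro on the other ring. Compound 2 gives only a limit, which leaves its standing against the other compounds open: the limit of >= 108 ug/mL in this assay, at which 1 of the 4 values shown sits.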